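Removing the Isopropylcarbonyl: Expectation for Compound 4

This account rests on a few compounds, and the source may have more. Where it says the series, first, only, none or still open, it means among the compounds named here.

Compound 1 `CC(C)C(=O)NCCS(=O)(=O)NC(=O)c1ccc(Nc2nc(NC3(c4ccc(Cl)cc4)CC3)nc(OCC(F)(F)F)n2)cc1` gives 84% in an ADME assay on microsomes from liver (Rattus norvegicus) for metabolic stability, with a stated time of 10 min (on this read-out lower numbers stand for a less stable compound and higher numbers for a more stable compound), the lowest of the three numbers measured. Compound 2 `COC(=O)NCCS(=O)(=O)NC(=O)c1ccc(Nc2nc(NC3(c4ccc(Cl)cc4)CC3)nc(OCC(F)(F)F)n2)cc1` gives 100% and compound 3 `CC(C)(C)CNCCS(=O)(=O)NC(=O)c1ccc(Nc2nc(NC3(c4ccc(Cl)cc4)CC3)nc(OCC(F)(F)F)n2)cc1` gives 90%; the step of a number 16 percentage points higher from compound 1 to compound 2 (beyond the scatter) lies beyond the scatter, whereas a number 6 percentage points higher from compound 1 to compound 3 (within the scatter) and a number 10 percentage points lower from compound 2 to compound 3 (within the scatter) stay within it. Compound 4 `NCCS(=O)(=O)NC(=O)c1ccc(Nc2nc(NC3(c4ccc(Cl)cc4)CC3)nc(OCC(F)(F)F)n2)cc1` differs from compound 1 as follows: hydrogen in place of isopropylcarbonyl on an amine nitrogen. Among the measured compounds shown here, the nearest measured step is the one from compound 1 to compound 3, where the isopropylcarbonyl also left the amine nitrogen and the number moved a number 6 percentage points higher from compound 1 to compound 3 (within the scatter); the step to compound 2 changed only the carbonyl substituent. Compound 4 is therefore expected to show no change beyond the scatter, with an estimated step of a number 4 percentage points higher from compound 1 to compound 4 (within the scatter). Compound 4 is estimated at 88%, between 72% and 100%.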

Compound 4, percent of the compound remaining: 100%
Beside the measured number, compound 4's estimate is 12 percentage points below it; low and high end bracket the measured number.
By their numbers in this assay, from the lowest: compounds 1, 3, 2 and 4 (each within the scatter of the next, the first and the last beyond it).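

Taking the isopropylcarbonyl off the amine nitrogen gives a number 16 percentage points higher from compound 1 to compound 4 (beyond the scatter) in this assay and so shows that this nitrogen needs no acyl group or other substituent to hold the number. The free amine also gives a number 10 percentage points higher from compound 3 to compound 4 (within the scatter) and no change at the digits printed from compound 2 to compound 4 (within the scatter) so neither neopentyl nor methoxycarbonyl can be told apart from hydrogen here. Nothing given here explains the step.

On these data alone, whether a methyl group on this nitrogen would behave the same stays open. So does the outcome for a longer chain in place of 2-aminoethyl, or for a carboxylic acid in place of the amine.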